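A few compounds are considered here, and "the series" means these few. Any claim that something is new, unique, unknown or untested is made for them only; others in the source may bear on it.

Measured so far:
compound 1 `C#CCSc1nc(Nc2ccccc2Cl)c(C#N)c(-c2ccccc2)n1`: 24200 nM
compound 2 `COc1ccc(Nc2nc(SCc3cn(Cc4ccccc4Cl)nn3)nc(-c3ccccc3)c2C#N)cc1`: 8050 nM

In a functional assay on MCF7 cells (Homo sapiens) for inhibition, read by MTT assay, with a stated time of 72 h (a lower number here means a stronger inhibitor, a higher number a weaker inhibitor), compound 1 gives 24200 nM while compound 2 gives 8050 nM; compound 2 thus holds the lowest of the two numbers, and its gap to compound 1 lies beyond the scatter. Compound 3 `N#Cc1c(Nc2ccc(Cl)cc2)nc(SCc2cn(Cc3ccccc3Cl)nn2)nc1-c1ccccc1` differs from compound 2 by chloro in place of methoxy on an aromatic carbon. Among the measured compounds shown here, no measured pair shows this change, so its direction is open; a small step, likely within the scatter, is expected in this assay. The expected step of a 1.2-fold lower number from compound 2 to compound 3 (0.06 log units; within the scatter) is accordingly modest. Compound 3 is estimated at 7000 nM, with a range of 2500 nM to 20000 nM.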

Compound 3, half-maximal inhibitory concentration: 6520 nM
Beside the measured number, compound 3's estimate is 1.1-fold (0.03 log units) above it; measured number inside the range.
By their numbers in this assay, from the lowest: compounds 3 and 2 (each within the scatter of the next); then compound 1.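

Chloro in place of methoxy gives the first single-place comparison in the series, (4-methoxyphenyl)amino to (4-chlorophenyl)amino. In this assay the step is a 1.2-fold lower number from compound 2 to compound 3 (0.09 log units; within the scatter), so this position, on an aromatic carbon para to a large group, does not tell the two groups apart. No available evidence bears on this result.

As far as these compounds go, whether an amine or a carboxylic acid at this position would move the number beyond the scatter remains open. Also open is which part of the structure accounts for the gap to compound 1.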